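Swapping a Naphthyl Group on a Triazole Core

The source may report more compounds than this note shows. Statements on the series, on what has been measured and on what is new or still open speak of the compounds shown alone.

Of the compounds shown here, three sharing one core have been tested in a functional assay on HeLa cells (Homo sapiens) for antiproliferative activity, with a stated time of 5 days; on this read-out higher numbers stand for weaker inhibition and lower numbers for stronger inhibition. Compound 1 `O=C1C=CC2(C=C1)OCC(=O)N2c1nc(-c2ccc3ccccc3c2Br)nn1-c1ccccc1` gives 290 nM. Compound 2 `Cc1ccc(-n2nc(-c3ccc4ccccc4c3)nc2N2C(=O)C(C)OC23C=CC(=O)C=C3)cc1` gives 530 nM, and compound 3 `O=C1C=CC2(C=C1)OCC(=O)N2c1nc(-c2ccc3ccccc3c2)nn1-c1ccc2ccccc2c1` gives 210 nM. Compound 1 sits close to both of the others: its gap to compound 3 and its gap to compound 2 are each within the usual scatter of repeated measurements, so the three cannot be told apart on these numbers.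

The next compound, compound 4 `O=C1C=CC2(C=C1)OCC(=O)N2c1nc(-c2cccc3ccccc23)nn1-c1ccccc1`, differs from compound 1 in a single place: naphthalen-1-yl in place of 1-bromonaphthalen-2-yl on an aromatic carbon. The bromine is lost and the naphthalene ring is joined to the core through a different carbon, while the count of rings stays the same and no hydrogen-bond donors or acceptors appear or disappear.

Within the data shown here, no pair among the measured compounds differs in exactly this way, so nothing measured speaks directly to the size of this change. Since the three measured numbers all sit together, the expected step from compound 1 to compound 4 in this assay is a 1.4-fold higher number from compound 1 to compound 4 (0.14 log units; within the scatter), with no direction expected beyond the scatter. Compound 4 is therefore estimated at 400 nM, within a range of 150 nM to 1100 nM.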

Compound 4, half-maximal inhibitory concentration: 70 nM
For compound 4 the middle estimate is 5.7-fold (0.76 log units) above the measured one; measured number below the stated range.
By their numbers in this assay, from the lowest: compound 4; then compounds 3, 1 and 2 (each within the scatter of the next, the first and the last beyond it).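

In this assay, the swap of 1-bromonaphthalen-2-yl for naphthalen-1-yl gives a 4.1-fold lower number from compound 1 to compound 4 (0.62 log units; beyond the scatter), which shows that the group on this aromatic carbon of the shared core can move the read-out by more than the scatter, something the closely grouped earlier numbers could not reveal. With the rest of the molecule held constant, including the phenyl group on the ring nitrogen, naphthalen-1-yl gives stronger inhibition of HeLa cell growth than 1-bromonaphthalen-2-yl. Nothing available here explains this gain in terms of how the two groups behave.

The single step changes two things together, the loss of the bromine and the carbon through which the naphthalene is joined, so the compounds shown cannot say which of the two matters or whether both do. As far as these compounds go, it also remains open how far this position tolerates other kinds of group, such as a simple pyridine ring, or a naphthalen-1-yl group carrying an amine or a carboxylic acid.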